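Swapping the aryl group on a hydrazone-bearing shared core

A few compounds are considered here, and "the series" means these few. Any claim that something is new, unique, unknown or untested is made for them only; others in the source may bear on it.

Three compounds share one core and differ only in the aryl group on a carbon with a double bond to nitrogen. Their results in a functional assay on HCT-116 cells (Homo sapiens) for antiproliferative activity, read by MTT assay (a lower number here means a stronger inhibitor, a higher number a weaker inhibitor), are:

Compound 1 `Cn1c(=O)c(=O)n(C2CCCC2)c2nc(N/N=C/c3ccc(O)cc3)ncc21`: 72500 nM
Compound 2 `Cn1c(=O)c(=O)n(C2CCCC2)c2nc(N/N=C/c3cccc(Cl)c3Cl)ncc21`: 26400 nM
Compound 3 `Cc1ccc(/C=N/Nc2ncc3c(n2)n(C2CCCC2)c(=O)c(=O)n3C)cc1C`: 62900 nM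

Compound 3 stands second highest of the three numbers in this assay; its nearest neighbour is compound 1, whose value sits within the scatter of it, while compound 2 lies furthest away, with a lower number beyond the scatter.

Compound 4 `Cn1c(=O)c(=O)n(C2CCCC2)c2nc(N/N=C/c3cc([N+](=O)[O-])ccc3Cl)ncc21` has not yet been measured. It differs from compound 3 in one place: 2-chloro-5-nitrophenyl in place of 3,4-dimethylphenyl on a carbon with a double bond to nitrogen.

Within the data shown here, two measured steps bear on this change. The step of a 1.2-fold lower number from compound 1 to compound 3 (0.06 log units; within the scatter) shows that 3,4-dimethylphenyl and 4-hydroxyphenyl give numbers within the scatter of each other. The step of a 2.4-fold higher number from compound 2 to compound 3 (0.38 log units; beyond the scatter) shows that moving from a chlorine-bearing ring to 3,4-dimethylphenyl gave a modest rise. Compound 4 again carries a chlorine on its ring, so a modest fall in this assay is expected, a 1.8-fold lower number from compound 3 to compound 4 (0.25 log units; within the scatter). Compound 4 is therefore estimated at 35000 nM, with a range from 15000 nM to 80000 nM.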

Compound 4, half-maximal inhibitory concentration: 5610 nM
Estimate against measurement, compound 4: 6.2-fold (0.80 log units) above; the whole stated range lies above it.
By their numbers in this assay, from the lowest: compound 4; then compound 2; then compounds 3 and 1 (each within the scatter of the next).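

In this assay the 2-chloro-5-nitrophenyl group gives an 11-fold lower number from compound 3 to compound 4 (1.05 log units; beyond the scatter) and a 13-fold lower number from compound 1 to compound 4 (1.11 log units; beyond the scatter) so this position, on a carbon with a double bond to nitrogen, can move the number much further than the earlier aryl swaps had shown. A chlorine on the ring does not settle the value either, since the change from 2,3-dichlorophenyl still gives a 4.7-fold lower number from compound 2 to compound 4 (0.67 log units; beyond the scatter) and the two chlorine-bearing rings are therefore not interchangeable here. No measurement is available to explain why this ring gives the lowest number of the four.

The compounds shown leave open whether the nitro group could produce this fall without the chlorine, as it appears only once and on a ring that also carries chlorine. They also leave open whether an amine or a carboxylic acid in place of the nitro group would keep the number this low.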